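The source may report more compounds than this note shows. Statements on the series, on what has been measured and on what is new or still open speak of the compounds shown alone.

Measured compounds:

Compound 1 `COc1ccc(CNc2nc([Se]C)nc3ccccc23)cc1` — 42200 nM
Compound 2 `[SeH]c1nc(NCc2ccccc2)c2cccnc2n1` — 30 nM
Compound 3 `C[Se]c1nc(NCc2ccccc2)c2ccccc2n1` — 15800 nM

In a functional assay on MCF7 cells (Homo sapiens) for cytotoxicity, read by MTT assay, with a stated time of 72 h (a higher number here means a weaker inhibitor of growth, a lower number a stronger inhibitor of growth), compound 1 gives 42200 nM, the highest number of the three. Going by the values given here, its nearest neighbour is compound 3, which gives 15800 nM; compound 2 is far away with 30 nM, a compound that differs from compound 1 in more than one place, so no single step can be drawn from it. Among the compounds with values here, the one step that can be drawn is a 2.7-fold lower number from compound 1 to compound 3 (0.43 log units; beyond the scatter), a modest change from hydrogen in place of methoxy on an aromatic carbon.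

Compound 4 `COc1ccc(CNc2nc(SC)nc3ccccc23)cc1` is the next compound. Its difference from compound 1 is a group of 2 heavy atoms (1 carbon, 1 sulfur; no ring) in place of a group of 2 heavy atoms (1 carbon, 1 selenium; no ring), on an aromatic carbon. Within the data shown here, none of the measured steps touches this exchange of selenium for sulfur in the methyl-bearing group, so there is no direct guide. Among the measured compounds shown here, the only measured step involves a different part of the molecule and was modest. Compound 2 shows that a selenium-bearing compound can reach a very low number, but it carries other changes as well, so it says nothing specific about this swap.

For compound 4 the expected step is a 1.1-fold lower number from compound 1 to compound 4 (0.02 log units; within the scatter), which means no change beyond the scatter, and the estimate is 40000 nM with a range from 14000 nM to 120000 nM.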

Compound 4, concentration for 50% growth inhibition: 30900 nM
Estimate against measurement, compound 4: 1.3-fold (0.11 log units) above; measured number inside the range.
By their numbers in this assay, from the lowest: compound 2; then compounds 3, 4 and 1 (each within the scatter of the next, the first and the last beyond it).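

In this assay the exchange at this position, on an aromatic carbon between two ring nitrogen atoms, is a 1.4-fold lower number from compound 1 to compound 4 (0.14 log units; within the scatter) and so stays within the usual scatter of repeated measurements. Going by these compounds alone, the earlier step concerned methoxy on another part of the molecule, so this is the first measured look at the selenium-bearing group itself: with the rest of compound 1 held fixed, methylsulfanyl can stand in its place with no change that can be told from the scatter. Within the data shown here, this means that in this pair selenium is not needed for the growth inhibition seen, although the result covers only this one exchange, and no independent measurement is available to explain it.

The compounds shown leave open whether sulfur and selenium would also match when the methoxy is replaced by hydrogen, or in a compound as active as compound 2. They also do not show how this position would respond to a different group, such as an amine, methoxy or a longer chain like ethylsulfanyl.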